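The source may report more compounds than this note shows. Statements on the series, on what has been measured and on what is new or still open speak of the compounds shown alone.

Compound 1 `O=c1ccc(-c2ccc3cn[nH]c3c2)cn1Cc1ccccc1`, compound 2 `CC(=O)Nc1cccc(Cn2cc(-c3ccc4c(N)n[nH]c4c3)ccc2=O)c1` and compound 3 `Nc1n[nH]c2cc(-c3ccc(=O)n(Cc4cccc(F)c4)c3)ccc12` have all been measured in an assay for inhibition of MAP kinase-interacting serine/threonine-protein kinase 1 (Homo sapiens), read by luminescence and ADP-Glo, with a stated time of 2 h; on this read-out lower numbers stand for stronger inhibition and higher numbers for weaker inhibition: compound 1 gives 315 nM, compound 2 gives 55 nM and compound 3 gives 19 nM.

Compound 3 thus stands lowest of the three, with compound 2 nearest and compound 1 furthest. Compound 4 `O=c1ccc(-c2ccc3cn[nH]c3c2)cn1Cc1cccc(F)c1` is obtained from compound 3 by a single change: hydrogen in place of amino on an aromatic carbon. For the measured compounds named here, no measured step touches that amino group; the only measured step, a 2.9-fold lower number from compound 2 to compound 3 (0.46 log units; beyond the scatter), concerns a different part of the molecule. Compound 1 lacks both the amino and the fluoro found in compound 3, and the gap between compound 1 and compound 3 is wider than that fluoro step alone. For compound 4 the expected step is a 5.3-fold higher number from compound 3 to compound 4 (0.72 log units; beyond the scatter), a weakening. Compound 4 is therefore estimated at 100 nM, between 40 nM and 250 nM.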

Compound 4, half-maximal inhibitory concentration: 74 nM
Beside the measured number, compound 4's estimate is 1.4-fold (0.13 log units) above it; low and high end bracket the measured number.
By their numbers in this assay, from the lowest: compound 3; then compounds 2 and 4 (each within the scatter of the next); then compound 1.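

Taking away the amino group, a 3.9-fold higher number from compound 3 to compound 4 (0.59 log units; beyond the scatter) in this assay, gives the first direct measure of what that group contributes on this carbon of the five-membered aromatic ring. Fluoro can now also be read on its own, without the amino group, as a 4.3-fold lower number from compound 1 to compound 4 (0.63 log units; beyond the scatter) on the same core. No evidence here accounts for either step. 

Going by these compounds, it remains open whether a methyl or hydroxyl group on that ring carbon would match amino. On these data alone, it is equally open how chloro or methoxy would compare with fluoro.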